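A few compounds are considered here, and "the series" means these few. Any claim that something is new, unique, unknown or untested is made for them only; others in the source may bear on it.

Of the compounds shown here, two have been measured in a functional assay on PC-3 cells (Homo sapiens) for antiproliferative activity, read by MTT assay, tested at 1 uM; on this read-out lower numbers stand for a weaker effect and higher numbers for a stronger effect at the one concentration tested. Compound 1, `COc1ccc(/C=N/NC(=O)c2cc(OC)c(OC)c(OC)c2)c(OC)c1`, gives 10% in this assay. Compound 2, `COc1cc(C2=NN(C(C)=O)C(c3c(Cl)cccc3Cl)O2)cc(OC)c1OC`, gives 5.1% in this assay. On these two numbers compound 2 stands beside compound 1: the gap between them lies within the scatter of repeated measurements, so neither compound can be called weaker or stronger than the other, and both read-outs are small at the single concentration tested.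

Compound 3, `COc1cc(C2=NN(C(C)=O)C(c3ccccc3F)O2)cc(OC)c1OC`, has not yet been measured in this assay. It differs from compound 2 in one place: 2-fluorophenyl in place of 2,6-dichlorophenyl on a saturated ring carbon.

For the measured compounds named here, no step between measured compounds is known that would show what such an exchange does in this assay, so the expectation for compound 3 rests on the weak read-outs of compound 1 and compound 2 alone. The step from compound 2 to compound 3 is expected to be a number 2.9 percentage points higher from compound 2 to compound 3 (within the scatter), which is not beyond the scatter. Compound 3 is therefore estimated to give 8% in this assay, with a range from 0% to 22%.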

Compound 3, a percentage reported as inhibition, at one concentration (the size of the read-out at that concentration, not a potency): 13.5%
Compound 3: middle estimate off by 5.5 percentage points, on the low side; the measured number falls inside the stated range.
By their numbers in this assay, from the lowest: compounds 2, 1 and 3 (each within the scatter of the next).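

For the compounds shown here, this is the first step that can be read at this position, the saturated ring carbon next to the ring oxygen and the ring nitrogen: in this assay, 2-fluorophenyl in place of 2,6-dichlorophenyl gives a number 8.4 percentage points higher from compound 2 to compound 3 (within the scatter). The shared core therefore carries either aryl group with no difference that stands clear of the scatter, so neither compound 2 nor compound 3 can be called the stronger, although the step changes both the kind and the count of halogen atoms at once and cannot separate the two. Nothing known about these compounds bears on what lies behind the two read-outs.

From the compounds shown here alone, it remains open whether a group of another kind on this ring carbon, such as an amine or a carboxylic acid, or a longer chain in place of the acetyl group, would move the read-out beyond the scatter. Because each read-out comes from a single concentration, the compounds shown also leave open how compound 2 and compound 3 would compare in potency.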